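The compounds below may be only part of what the source reports. "The series", "measured", "known", "first", "only" and "open" are said of these compounds alone.

Measured in a physicochemical assay for lipophilicity, measured as octanol-water partition, at pH 7.4; a higher number here means a more lipophilic compound, a lower number a more polar compound:
Compound 1 `Cc1cc(-c2nc3ccccc3s2)ccc1N`: 3.96
Compound 2 `Nc1ccc(-c2nc3ccccc3s2)cc1I`: > 3.3 (a limit, not a number)

Compound 2 gives no number in this assay, only the limit > 3.3. It stands at the limit of > 3.3 in this assay, at which 1 of the 2 values shown sits. Compound 3 `Nc1ccc(-c2nc3ccccc3s2)cc1Br` is still to be measured, and it differs from compound 2 as follows: bromo in place of iodo on an aromatic carbon. Among the measured compounds shown here, one measured step bears on this change, a step that the limit leaves unreadable from compound 1 to compound 2, where iodo replaces methyl on an aromatic carbon. That step gives no size to carry over, so neither the size nor the direction of the change in this assay can be read from it. For the measured compounds named here, the estimate therefore leans on compound 1 , the only true number at 3.96, and it stays wide. The expected change is a step that the limit leaves unreadable from compound 2 to compound 3. Compound 3 is expected at 3.8, with an estimated range from 3.3 to 4.3.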

Compound 3, distribution coefficient: > 3.3
Compound 3 was reported as a limit; the forecaster's own chance of this, stated with the estimate: 40%; the middle value is on the limit's open side.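

No step among compound 1, compound 2 and compound 3 can be read in this assay, because compound 2 and compound 3 each give only a limit: the limit of > 3.3 in this assay, at which 2 of the 3 values shown sit.

The compounds shown leave open whether, and how far, methyl, iodo and bromo on this aromatic carbon differ in this assay.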